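The compounds below may be only part of what the source reports. "The series", "measured", "known", "first", "only" and "open" are said of these compounds alone.

Compound 1 `Cc1ccc(Oc2ccc(C#N)cc2S(=O)(=O)NC(=O)NC(C)(C)C)cc1` is the reference point here. In a functional assay on HEK293 cells for antagonist activity at thromboxane A2 receptor (Homo sapiens), read by fluorescence and calcium flux (a higher number here means a weaker inhibitor, a lower number a stronger inhibitor), compound 1 gives 750 nM, the lowest of the three numbers available. Its nearest neighbour is compound 2 `CCCCCNC(=O)NS(=O)(=O)c1cc(C#N)ccc1Oc1ccc(C)cc1`, which in this assay gives 900 nM; the two differ only in the group carried on the urea nitrogen, and the step of a 1.2-fold higher number from compound 1 to compound 2 (0.08 log units; within the scatter) does not separate them. The furthest is compound 3 `CC(C)NC(=O)NS(=O)(=O)c1cc(C#N)ccc1Oc1ccc(Cl)cc1`, which in this assay gives 9460 nM; compound 3 differs from compound 1 in two places at once, so its weaker result cannot be attributed to either change alone.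

Compound 4 `CC(C)(C)NC(=O)NS(=O)(=O)c1cc(C#N)ccc1Oc1ccc(Br)cc1` keeps the tert-butyl urea of compound 1 and alters only the outer ring: bromo in place of methyl on an aromatic carbon. Among the measured compounds shown here, no measured step changes that position on its own. For the measured compounds named here, the single measured step concerns the urea substituent and is within the scatter, so it says nothing direct about a halogen on the ring, while compound 3 carries a chloro at that position but also a different urea group. The expectation for compound 4 is therefore a modest move towards a higher number, with wide uncertainty, and an estimated step of a 2.0-fold higher number from compound 1 to compound 4 (0.30 log units; within the scatter). Compound 4 is expected to give about 1500 nM, with a likely range from 400 nM to 6000 nM.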

Compound 4, half-maximal inhibitory concentration: 5880 nM
The estimate for compound 4 lay 3.9-fold (0.59 log units) below the measured number; measured number inside the range.
By their numbers in this assay, from the lowest: compounds 1 and 2 (each within the scatter of the next); then compounds 4 and 3 (each within the scatter of the next).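

Among the compounds shown here, the outer ring is the first place in this set where a single change shifts the result beyond the scatter: with bromo in place of methyl, this assay shows a 7.8-fold higher number from compound 1 to compound 4 (0.89 log units; beyond the scatter), whereas changing the urea substituent gave only a 1.2-fold higher number from compound 1 to compound 2 (0.08 log units; within the scatter). For the compounds shown here, this means that, between these compounds, the change on the aromatic carbon para to a large group matters more than the one measured change on the urea nitrogen, and a methyl there gives the stronger inhibitor. The swap is a small one on paper, since one heavy atom leaves, one enters, and neither brings a hydrogen-bond donor, an acceptor or a net charge, and nothing available here explains why the number moves so far.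

Going by these compounds, it remains open whether this loss belongs to bromo alone or would also appear with other groups at this position, such as fluoro, methoxy, ethyl or a plain hydrogen, and compound 3 cannot settle this for chloro as its urea group differs too. Also unknown is whether a pentyl urea would behave on the 4-bromophenoxy compound as it does on the 4-methylphenoxy compound.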